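This account rests on a few compounds, and the source may have more. Where it says the series, first, only, none or still open, it means among the compounds named here.

Compound 1 `Cc1ccc2[nH]c(-c3cn(-c4ccccc4)nc3-c3ccc(F)cc3)nc2c1`: 1120 nM
Compound 2 `Fc1ccc(-c2nn(-c3ccccc3)cc2-c2nc3cc(C(F)(F)F)ccc3[nH]2)cc1`: 2130 nM
Compound 3 `FC(F)(F)c1ccc2[nH]c(-c3cn(-c4ccccc4)nc3-c3ccc(Cl)cc3)nc2c1`: 4210 nM

These three compounds have been tested in a functional assay on MCF7 cells (Homo sapiens) for antiproliferative activity, read by MTT assay, with a stated time of 48 h; on this read-out higher numbers stand for weaker inhibition and lower numbers for stronger inhibition. Compound 4 `Cc1ccc2[nH]c(-c3cn(-c4ccccc4)nc3-c3ccc(Cl)cc3)nc2c1` has not yet been measured there. Compound 4 differs from compound 3 in one place: methyl in place of trifluoromethyl on an aromatic carbon. The same change has been made once before, from compound 2 to compound 1: methyl in place of trifluoromethyl on an aromatic carbon. In this assay that earlier change gave a 1.9-fold lower number from compound 2 to compound 1 (0.28 log units; within the scatter). The surroundings of the changed group read the same in both cases, so this is the same change on two cores. The core of compound 3 differs from the core of compound 2 in one place: chloro in place of fluoro on an aromatic carbon. That difference gave a 2.0-fold higher number from compound 2 to compound 3 (0.30 log units; within the scatter). The values of compound 3 and compound 1 lie further apart than the scatter, while compound 3 and compound 2 lie within it.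

For compound 4 the expected step is a 1.9-fold lower number from compound 3 to compound 4 (0.28 log units; within the scatter) because the same change on the other core gave a 1.9-fold lower number from compound 2 to compound 1 (0.28 log units; within the scatter). Compound 4 is therefore estimated at 2200 nM, with a likely range from 1100 nM to 4400 nM. What the measurement shows is told next.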

Compound 4, half-maximal inhibitory concentration: 8230 nM
The estimate for compound 4 lay 3.7-fold (0.57 log units) below the measured number, and the stated range ends below it.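

In this assay, methyl in place of trifluoromethyl did not carry over from one core to the other. It gave a 2.0-fold higher number from compound 3 to compound 4 (0.29 log units; within the scatter), which points the opposite way to the earlier step, and although each step alone lies within the scatter, the gap between them does not: the same change on two cores in this assay, a 1.9-fold lower number (0.28 log units; within the scatter) from compound 2 to compound 1 and a 2.0-fold higher number (0.29 log units; within the scatter) from compound 3 to compound 4, 3.7-fold (0.57 log units) apart, beyond the scatter of two such steps. Seen from the other side of the same four compounds, chloro in place of fluoro gave a 7.3-fold higher number from compound 1 to compound 4 (0.87 log units; beyond the scatter), so the effect of the halogen depends on which group the shared core carries at the other site: the same change on two cores in this assay, a 2.0-fold higher number (0.30 log units; within the scatter) from compound 2 to compound 3 and a 7.3-fold higher number (0.87 log units; beyond the scatter) from compound 1 to compound 4, 3.7-fold (0.57 log units) apart, beyond the scatter of two such steps. This shows that the two changes do not simply add up in these compounds, but it does not show why, and one set of four compounds cannot say how often this happens elsewhere in the series.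

Still open, from the compounds shown here alone, is how a bromo group, or no halogen at all, would behave on the phenyl ring that carries the halogen here. Also open, going by these compounds, is whether a methoxy group, a nitrile or an amine in place of methyl would follow compound 1 or compound 4.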